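The compounds below may be only part of what the source reports. "The series", "measured", "known", "first", "only" and "open" are said of these compounds alone.

In an assay on membranes from brain for displacement of a labelled ligand from Neuronal acetylcholine receptor; alpha4/beta2 (Rattus norvegicus), with a stated time of 3 h (on this read-out higher numbers stand for weaker inhibition and lower numbers for stronger inhibition), compound 1 `Cc1cc(/C=C2\CCCN=C2c2cccnc2)cc(C)c1O` gives 360 nM, compound 2 `CCCCOc1ccc(/C=C2\CCCN=C2c2cccnc2)cc1` gives 1960 nM, and compound 3 `CCCc1ccc(/C=C2\CCCN=C2c2cccnc2)cc1` gives 890 nM. Compound 3 therefore stands second highest of the three numbers: compound 2 sits nearest, and compound 1 furthest from it. For the measured compounds named here, the one step measured at the same place on the ring is a 2.2-fold lower number from compound 2 to compound 3 (0.34 log units; beyond the scatter), a change of an alkoxy chain to an alkyl chain at that position.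

Compound 4 `CSc1ccc(/C=C2\CCCN=C2c2cccnc2)cc1` differs from compound 3 by methylsulfanyl in place of propyl on an aromatic carbon. Going by the values given here, no measured pair shows this exact exchange; the step from compound 2 to compound 3 is only a partial guide, since it concerns a longer oxygen-bearing chain rather than a sulfur-bearing one. On that basis the expected step from compound 3 to compound 4 in this assay is small and of uncertain direction, a 1.3-fold lower number from compound 3 to compound 4 (0.10 log units; within the scatter), and may not pass beyond the scatter. The estimate for compound 4 in this assay is 700 nM, with a range from 250 nM to 2000 nM.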

Compound 4, inhibition constant: 900 nM
Beside the measured number, compound 4's estimate is 1.3-fold (0.11 log units) below it, and the stated range covers the measured number.
By their numbers in this assay, from the lowest: compound 1; then compounds 3 and 4 (each within the scatter of the next); then compound 2.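

In this assay, methylsulfanyl in place of propyl on an aromatic carbon, para to a large group, gives a 1.0-fold higher number from compound 3 to compound 4 (0.00 log units; within the scatter), so these two compounds cannot be told apart, even though the entering group holds a sulfur atom and the leaving one holds carbon only. Butoxy is now set apart from two different groups at this position, with a 2.2-fold lower number from compound 2 to compound 4 (0.34 log units; beyond the scatter) alongside a 2.2-fold lower number from compound 2 to compound 3 (0.34 log units; beyond the scatter), although both steps are modest. No measurement shown here explains why methylsulfanyl and propyl read alike.

On these data alone, whether an amine, a carboxylic acid or a longer alkyl chain at this position would shift the number remains open. Compound 1 differs from these compounds in more than one place, so the separate contributions of its hydroxyl and two methyl groups also stay unresolved.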